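The compounds below may be only part of what the source reports. "The series", "measured", "known", "first", "only" and "open" are said of these compounds alone.

Measured so far:
Compound 1 `COc1ccc(-c2cc3ccccc3c(-c3ccc(O)cc3)n2)cc1`: in an ADME assay on MCF-10A cells (Homo sapiens) for cytotoxicity, read by CCK-8 assay and cell counting, with a stated time of 72 h (a higher number here means a weaker inhibitor, a lower number a stronger inhibitor), compound 1 gives > 50000 nM, a limit of the assay.
Compound 2 `COc1ccc(-c2cc3ccccc3c(-c3ccc(OC)cc3)n2)cc1`: in this assay compound 2 gives > 50000 nM, again a limit.
For the measured compounds named here, compound 3 `COc1ccc(-c2cc3cc(C)ccc3c(-c3cccc(O)c3)n2)cc1OC`: in this assay compound 3 gives 13500 nM, the only number among the three.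

Compound 4 `COc1cccc(-c2nc(-c3ccc(OC)c(OC)c3)cc3cc(C)ccc23)c1` remains to be measured. Compound 3 and compound 4 differ by methyl in place of hydrogen on an oxygen on an aromatic ring. The same change, (methyl in place of hydrogen on an oxygen on an aromatic ring), joins compound 1 to compound 2; there the step that the two limits leave unreadable from compound 1 to compound 2 stays unreadable because of the limit of > 50000 nM in this assay, at which 2 of the 3 values shown sit. The difference between the core of compound 1 and the core of compound 3 is not broken down here. For compound 4 the step from compound 3 is expected as a 1.9-fold higher number from compound 3 to compound 4 (0.27 log units; within the scatter), resting on compound 3 at 13500 nM and on the fact that a step that the two limits leave unreadable from compound 1 to compound 2 gives no direction. Compound 4 is therefore expected near 25000 nM, plausibly between 8000 nM and 80000 nM.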

Compound 4, half-maximal inhibitory concentration: > 50000 nM
Compound 4: no number, only a limit (the forecaster's own chance of this, stated with the estimate: 40%); middle value at least 2.0-fold (0.30 log units) away from the limit.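

In this assay, methyl in place of hydrogen on the oxygen gives an at least 3.7-fold higher number from compound 3 to compound 4 (0.56 log units; beyond the scatter), so on the core of compound 3 the change from 3-hydroxyphenyl to 3-methoxyphenyl raises the number beyond the scatter, and the true size of the step may be larger. Compound 4 gives > 50000 nM, which is a limit. The same change on the core of compound 1 cannot be read, so one readable step shows no transfer between the two cores, in either size or direction: the limit of > 50000 nM in this assay, at which 3 of the 4 values shown sit.

The compounds shown leave open how an amine or a carboxylic acid in place of the hydroxy group would read in this assay. From the compounds shown here alone, a longer chain on the oxygen, such as ethoxy, also remains open.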